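A few compounds are considered here, and "the series" means these few. Any claim that something is new, unique, unknown or untested is made for them only; others in the source may bear on it.

Notes on the series. Compound 3 `COc1cc2nc([S+]([O-])CC(=O)Nc3ccc(C(F)(F)F)cc3)nc(Nc3c(Cl)cc(/C=C/C#N)cc3Cl)c2cc1OC` is the starting point of the next step. In an ADME assay on MT4 cells (Homo sapiens) for cytotoxicity, read by MTT assay, with a stated time of 5 days (a higher number here means that more compound is tolerated, a lower number that less compound is tolerated), compound 3 gives 22000 nM, the lowest of the two numbers in hand. Its nearest neighbour is compound 2 `COc1cc2nc([S+]([O-])CC(=O)Nc3ccc([N+](=O)[O-])cc3)nc(Nc3c(Cl)cc(/C=C/C#N)cc3Cl)c2cc1OC`, which in this assay gives 92800 nM, and the step of a 4.2-fold lower number from compound 2 to compound 3 (0.63 log units; beyond the scatter) separates the two. Compound 1 `COc1cc2nc([S+]([O-])CC(=O)Nc3cccc([N+](=O)[O-])c3)nc(Nc3c(Cl)cc(/C=C/C#N)cc3Cl)c2cc1OC` in this assay gives only a limit, >= 83200 nM. The step that the limit leaves unreadable from compound 1 to compound 2 cannot be sized, while the step of an at least 3.7-fold lower number from compound 1 to compound 3 (0.57 log units; beyond the scatter) is readable at one end only, given (the limit of >= 83200 nM in this assay, at which 1 of the 3 values shown sits).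

Compound 4 `COc1ccccc1NC(=O)C[S+]([O-])c1nc(Nc2c(Cl)cc(/C=C/C#N)cc2Cl)c2cc(OC)c(OC)cc2n1` differs from compound 3 in one place: 2-methoxyphenyl in place of 4-(trifluoromethyl)phenyl on an amide-type nitrogen. For the measured compounds named here, no measured step exchanges these two groups directly; the closest comparison is a 4.2-fold lower number from compound 2 to compound 3 (0.63 log units; beyond the scatter), in which the trifluoromethyl group sat on the side of the lower number. Compound 4, losing that group, is therefore expected to move back upward by about a 2.3-fold higher number from compound 3 to compound 4 (0.36 log units; beyond the scatter). A limit, as for compound 1, remains possible. Compound 4 is expected to give 50000 nM in this assay, within 20000 nM to 120000 nM.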

Compound 4, half-maximal cytotoxic concentration: > 204000 nM
Compound 4: a limit, no number (the forecaster's own chance of this, stated with the estimate: 20%); middle value at least 4.0-fold (0.61 log units) from the limit.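

In this assay compound 4 gives only a limit, not a number: the limit of > 204000 nM in this assay, at which 1 of the 4 values shown sits. With 2-methoxyphenyl on the amide-type nitrogen, the series shows an at least 9.2-fold higher number from compound 3 to compound 4 (0.96 log units; beyond the scatter) and an at least 2.1-fold higher number from compound 2 to compound 4 (0.34 log units; beyond the scatter), so this position can carry a group without trifluoromethyl or nitro and still move the number upward beyond the scatter, further than the earlier nitro-to-trifluoromethyl exchange could show. The steps in which limits leave the size unknown cannot be read, and compound 1 and compound 4 stay unordered: the limit of >= 83200 nM in this assay, at which 1 of the 4 values shown sits.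

On these data alone, it remains open whether the higher number belongs to the methoxy group itself or to the place it holds on the phenyl ring, and the true size of both steps is unknown. As far as these compounds go, how an amine or a carboxylic acid on that phenyl ring would read in this assay also stays open.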